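This account rests on a few compounds, and the source may have more. Where it says the series, first, only, none or still open, it means among the compounds named here.

Measured compounds:
Compound 1, `O=S(=O)(NCCNCc1ccc(-c2ccccc2)cc1)c1cc(C(F)(F)F)cc(C(F)(F)F)c1`, 2400 nM
Compound 2, `O=S(=O)(NCCCNCc1ccccc1Cl)c1cc(C(F)(F)F)cc(C(F)(F)F)c1`, 13000 nM
Compound 3, `O=S(=O)(NCCNCc1cccc2ccccc12)c1cc(C(F)(F)F)cc(C(F)(F)F)c1`, 21000 nM

These three compounds were tested in a functional assay on Capan-2 cells (Homo sapiens) for inhibition, read by MTT assay, with a stated time of 72 h; on this read-out lower numbers stand for stronger inhibition of growth and higher numbers for weaker inhibition of growth. Among the three numbers, compound 2 gives the second highest. Its nearest neighbour is compound 3, whose number is within the usual scatter of the value of compound 2, so the two cannot be told apart on this read-out. Its furthest neighbour is compound 1, whose lower number lies beyond the scatter, so compound 1 inhibits growth more strongly than compound 2.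

Compound 4, `COc1ccc(CNCCCNS(=O)(=O)c2cc(C(F)(F)F)cc(C(F)(F)F)c2)cc1`, has not yet been measured. It differs from compound 2 in one place: 4-methoxyphenyl in place of 2-chlorophenyl on a saturated chain carbon bound to an amine nitrogen. Within the data shown here, no measured pair shows this particular exchange, so there is no direct precedent for its size or direction in this assay. The remaining compounds change other parts of the molecule, and their numbers spread both above and below that of compound 2 without pointing one way. The expectation is therefore a step from compound 2 to compound 4 of no more than the scatter, in either direction, as a 1.2-fold lower number from compound 2 to compound 4 (0.07 log units; within the scatter) expresses. On that basis compound 4 is estimated at 11000 nM, with a range from 3000 nM to 40000 nM.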

Compound 4, concentration for 50% growth inhibition: 2400 nM
The estimate for compound 4 lay 4.6-fold (0.66 log units) above the measured number, outside the stated range (below it).
By their numbers in this assay, from the lowest: compounds 1 and 4 (each within the scatter of the next); then compounds 2 and 3 (each within the scatter of the next).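

In this assay, 4-methoxyphenyl in place of 2-chlorophenyl on a saturated chain carbon bound to an amine nitrogen gives a 5.4-fold lower number from compound 2 to compound 4 (0.73 log units; beyond the scatter), which shows that growth inhibition in this series responds to the group at this place and that the group is not a silent passenger. The exchange alters more than one feature at once: chlorine leaves and oxygen enters, the count goes from 0 hydrogen-bond acceptors to 1 hydrogen-bond acceptor, and the substituent's ring position changes, as the two group names show. No measurement here links the step to any one of these features, so its origin remains unexplained.

The compounds shown leave open whether the step follows the arrival of the methoxy group, the departure of the chlorine or the change of ring position, and phenyl, 4-chlorophenyl and 2-methoxyphenyl at this same place would help separate these readings. Going by these compounds, it is also open whether a larger ether such as 4-ethoxyphenyl, or an amine such as 4-(dimethylamino)phenyl, would fit the same trend.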